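A few compounds are considered here, and "the series" means these few. Any claim that something is new, unique, unknown or untested is made for them only; others in the source may bear on it.

Compound 3 `N#Cc1ccc(Nc2nccc(N(CCCO)c3c(F)cc(-c4ccc(C#N)cc4)cc3F)n2)cc1` gives 68000 nM in an ADME assay on MT4 cells (Homo sapiens) for cytotoxicity, read by MTT assay, with a stated time of 5 days (on this read-out higher numbers stand for lower toxicity in this test and lower numbers for higher toxicity in this test), the lowest of the two numbers available. Compound 1 `CC(C)CN(c1ccnc(Nc2ccc(C#N)cc2)n1)c1c(F)cc(-c2ccc(C#N)cc2)cc1F` gives 241000 nM in this assay. Compound 2 `CCC(C)CN(c1ccnc(Nc2ccc(C#N)cc2)n1)c1c(F)cc(-c2ccc(C#N)cc2)cc1F` reaches the assay limit rather than a number, > 255000 nM. Compound 4 `N#CCN(c1ccnc(Nc2ccc(C#N)cc2)n1)c1c(F)cc(-c2ccc(C#N)cc2)cc1F` differs from compound 3 by cyano in place of 2-hydroxyethyl on a saturated chain carbon bound to a nitrogen on an aromatic ring. For the measured compounds named here, the steps that bear on this change are a 3.5-fold lower number from compound 1 to compound 3 (0.55 log units; beyond the scatter) and an at least 3.7-fold lower number from compound 2 to compound 3 (0.57 log units; beyond the scatter), both beyond the scatter, while an at least 1.0-fold higher number from compound 1 to compound 2 (0.02 log units; that floor lies within the scatter) stays within it; one of the values sits at the limit of > 255000 nM in this assay, at which 1 of the 3 values shown sits. Since a 3.5-fold lower number from compound 1 to compound 3 (0.55 log units; beyond the scatter) and an at least 3.7-fold lower number from compound 2 to compound 3 (0.57 log units; beyond the scatter) both lower the number as 2-hydroxyethyl enters, its removal in compound 4 is expected to raise it, an expected step of a 2.2-fold higher number from compound 3 to compound 4 (0.34 log units; beyond the scatter). The estimate for compound 4 is 150000 nM, within 50000 nM to 255000 nM.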

Compound 4, half-maximal cytotoxic concentration: 206000 nM
For compound 4 the middle estimate is 1.4-fold (0.14 log units) below the measured one; low and high end bracket the measured number.
By their numbers in this assay, from the lowest: compound 3; then compounds 4 and 1 (each within the scatter of the next). At a limit, above all of these: compound 2.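

In this assay, the lower number seen with 2-hydroxyethyl does not persist with cyano at this position: a 3.0-fold higher number from compound 3 to compound 4 (0.48 log units; beyond the scatter). Cyano in place of isopropyl gives a 1.2-fold lower number from compound 1 to compound 4 (0.07 log units; within the scatter), so the two cannot be told apart here and a branched alkyl chain is not required for the higher numbers. Cyano in place of sec-butyl gives an at least 1.2-fold lower number from compound 2 to compound 4 (0.09 log units; that floor lies within the scatter). Compound 2 stands at a limit of the assay: the limit of > 255000 nM in this assay, at which 1 of the 4 values shown sits.

Compound 3 alone carries the hydroxyl, so the series cannot separate the hydroxyl from the chain that holds it. A methoxy-ended chain or an amine at this position would test that.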